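Piperazine-linked indole amides: cytotoxicity in neuroblastoma cells

The compounds below may be only part of what the source reports. "The series", "measured", "known", "first", "only" and "open" are said of these compounds alone.

The series shares a core built from two piperazines joined through an acetyl bridge, an indolylpropyl chain on one side and an aroyl group on the other. Compound 1 `O=C(CN1CCN(C(=O)c2ccc(F)cc2)CC1)N1CCN(CCCc2c[nH]c3ccccc23)CC1` carries a 4-fluorophenyl on the carbonyl carbon; in an ADME assay on SH-SY5Y cells (Homo sapiens) for cytotoxicity, read by MTT assay, with a stated time of 72 h (on this read-out higher numbers stand for weaker inhibition and lower numbers for stronger inhibition), compound 1 gives 188000 nM. Compound 2 `O=C(CN1CCN(C(=O)c2cccc(Cl)c2)CC1)N1CCN(CCCc2c[nH]c3ccccc23)CC1` differs by 3-chlorophenyl in place of 4-fluorophenyl on a carbonyl carbon; in this assay compound 2 gives 120000 nM, and the step is a 1.6-fold lower number from compound 1 to compound 2 (0.19 log units; within the scatter). Compound 3 `O=C(CN1CCN(C(=O)c2ccc(F)cc2)CC1)N1CCN(CCCc2c[nH]c3ccc(F)cc23)CC1` keeps the 4-fluorophenyl but changes the core by fluoro in place of hydrogen on an aromatic carbon; in this assay compound 3 gives 121000 nM, a step of a 1.6-fold lower number from compound 1 to compound 3 (0.19 log units; within the scatter). The values of compound 2 and compound 3 lie within the scatter of each other.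

Compound 4 `O=C(CN1CCN(C(=O)c2cccc(Cl)c2)CC1)N1CCN(CCCc2c[nH]c3ccc(F)cc23)CC1` has not been measured. It stands to compound 3 as compound 2 stands to compound 1, by 3-chlorophenyl in place of 4-fluorophenyl on a carbonyl carbon, and the place of the change reads the same in both pairs, so it is the same change on the fluorinated core. Because a 1.6-fold lower number from compound 1 to compound 2 (0.19 log units; within the scatter) was within the scatter, the expected step is a 1.4-fold lower number from compound 3 to compound 4 (0.15 log units; within the scatter), a small one. Compound 4 is therefore estimated at 85000 nM in this assay, expected to fall between 40000 nM and 190000 nM.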

Compound 4, half-maximal inhibitory concentration: 59800 nM
Compound 4: the middle estimate sits 1.4-fold (0.15 log units) above what was measured; low and high end bracket the measured number.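

Notes on carrying the changes: 3-chlorophenyl in place of 4-fluorophenyl on a carbonyl carbon gives, on the fluorinated core, a 2.0-fold lower number from compound 3 to compound 4 (0.31 log units; beyond the scatter), and this step does not differ from the one on the core of compound 1: the same change on two cores in this assay, a 1.6-fold lower number (0.19 log units; within the scatter) from compound 1 to compound 2 and a 2.0-fold lower number (0.31 log units; beyond the scatter) from compound 3 to compound 4, 1.3-fold (0.11 log units) apart, within the scatter of two such steps. Fluoro in place of hydrogen on an aromatic carbon gives, with 3-chlorophenyl in place, a 2.0-fold lower number from compound 2 to compound 4 (0.30 log units; within the scatter), and this step also matches its earlier counterpart: the same change on two cores in this assay, a 1.6-fold lower number (0.19 log units; within the scatter) from compound 1 to compound 3 and a 2.0-fold lower number (0.30 log units; within the scatter) from compound 2 to compound 4, 1.3-fold (0.11 log units) apart, within the scatter of two such steps. In this assay, going by these compounds alone, each change therefore carries from one core to the other within these four compounds, but only the step to compound 4 from compound 3 lies beyond the scatter, and it is modest, so a single set of four compounds does not show a general rule for the series.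

Still open, going by these compounds, is whether the same holds for an amine or a carboxylic acid on the aroyl ring. A longer chain in place of the indolylpropyl chain is also untested by the compounds shown here.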